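Chloro to Bromo on One Aromatic Carbon

The source may report more compounds than this note shows. Statements on the series, on what has been measured and on what is new or still open speak of the compounds shown alone.

In an ADME assay on GES1 cells (Homo sapiens) for cytotoxicity, read by MTT assay, with a stated time of 24 h (on this read-out higher numbers stand for lower toxicity in this test and lower numbers for higher toxicity in this test), compound 1 `CC1(C)[C@H]2CC[C@]1(C)N(Cc1cn(-c3ccccc3C#N)nn1)C(=O)C2` gives 9450 nM and compound 2 `CC1(C)[C@H]2CC[C@]1(C)N(Cc1cn(-c3cccc(Cl)c3)nn1)C(=O)C2` gives 69800 nM as the higher of the two numbers. Compound 3 `CC1(C)[C@H]2CC[C@]1(C)N(Cc1cn(-c3cccc(Br)c3)nn1)C(=O)C2` differs from compound 2 by bromo in place of chloro on an aromatic carbon with bromo in place of chloro on an aromatic carbon. Among the measured compounds shown here, the only measured step that bears on this is a 7.4-fold higher number from compound 1 to compound 2 (0.87 log units; beyond the scatter) and it exchanged 2-cyanophenyl for 3-chlorophenyl, so it says little about a swap of chloro for bromo. No step beyond the scatter is therefore expected in this assay in either direction. Compound 3 is expected at 62000 nM with 27000 nM to 130000 nM as its likely range.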

Compound 3, half-maximal cytotoxic concentration: 9930 nM
Compound 3: middle estimate off by 6.2-fold (0.80 log units), on the high side; measured number outside the range, below it.
By their numbers in this assay, from the lowest: compounds 1 and 3 (each within the scatter of the next); then compound 2.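

In this assay the choice of halogen at this place matters: exchanging chloro for bromo alone gives a step beyond the scatter (a 7.0-fold lower number from compound 2 to compound 3 (0.85 log units; beyond the scatter)). The 3-bromophenyl and 2-cyanophenyl groups read within the scatter of each other (a 1.1-fold higher number from compound 1 to compound 3 (0.02 log units; within the scatter)), so the high number in this set belongs to 3-chlorophenyl, not to any halogen on this ring. Nothing measured here accounts for this step.

The compounds shown leave open where fluoro, iodo or methoxy at this place would fall. They also leave open whether chloro keeps its high number elsewhere on the ring.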